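Two limits and a chloro compound

This account rests on a few compounds, and the source may have more. Where it says the series, first, only, none or still open, it means among the compounds named here.

Compound 1 `CCn1c(/C=C2/C(=O)Nc3ccc(C)cc32)nc2ccccc21`: > 50000 nM, a limit
Compound 2 `Cn1c(/C=C2/C(=O)Nc3ccc([N+](=O)[O-])cc32)nc2ccccc21`: > 50000 nM, a limit

Neither compound has yet given a number in a functional assay on A549 cells (Homo sapiens) for cytotoxicity, read by MTT assay, with a stated time of 48 h; a lower number here means a stronger inhibitor, a higher number a weaker inhibitor. Compound 2 stands at > 50000 nM, which is a limit of the assay and not a measured potency. The record so far comes down to the limit of > 50000 nM in this assay, at which 2 of the 2 values shown sit. Among the compounds with values here, no step between measured compounds is available, so nothing yet shows how far a single change can move the read-out on the shared core.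

Compound 3 `Cn1c(/C=C2/C(=O)Nc3ccc(Cl)cc32)nc2ccccc21` has chloro in place of nitro on an aromatic carbon, para to a fused ring and meta to a fused ring: chloro in place of nitro on an aromatic carbon. The expectation for it rests mainly on compound 2 at > 50000 nM, again a limit. No change beyond the scatter is expected in this assay, and another limit is the likeliest reading. The estimated shift is an at least 1.1-fold lower number from compound 2 to compound 3 (0.04 log units; that floor lies within the scatter). If a number is reported, compound 3 is expected at 45000 nM, with an estimated range of 15000 nM to 100000 nM.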

Compound 3, half-maximal inhibitory concentration: 39700 nM
For compound 3 the middle estimate is 1.1-fold (0.05 log units) above the measured one; the range from low to high includes it.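

In this assay compound 3 gives the only measured number among the compounds shown, 39700 nM, so this aromatic carbon, para to a fused ring and meta to a fused ring, can carry a group that brings the read-out within the range of the assay. The change of nitro to chloro, with one heavy atom entering where three leave and no hydrogen-bond acceptor remaining in that group, gives an at least 1.2-fold lower number from compound 2 to compound 3 (0.10 log units; that floor lies within the scatter); because the value of compound 2 is a limit and not a number, this is only a floor, and the true size of the step cannot be read from it. The series as a whole still rests largely on such limits, so a single number gives little to compare it with: the limit of > 50000 nM in this assay, at which 2 of the 3 values shown sit.

Going by these compounds, whether an amine or a carboxylic acid on this aromatic carbon would move the read-out beyond the scatter from compound 3 remains open. Compound 1 differs from compound 3 in more than one place, so the compounds shown give no separate reading of a longer chain on the shared core.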